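This account rests on a few compounds, and the source may have more. Where it says the series, first, only, none or still open, it means among the compounds named here.

Working notes on the series. Three compounds have so far been run in a physicochemical assay for lipophilicity, using the shake flask method, in phosphate buffer, measured as octanol-water partition, with a stated time of 30 min, at pH 7.4; on this read-out higher numbers stand for higher lipophilicity and lower numbers for lower lipophilicity. Compound 1 `C[C@@H]1CC(=O)N(c2cnc(NCc3c(F)ccc4c3CCO4)n3cnnc23)C1` gives 1.8, compound 3 `CN(C(=O)c1ccccc1)c1cnc(NCc2c(F)ccc3c2CCO3)n2cnnc12` gives 2.4, and compound 2 `Cc1nc(CO)ccc1-c1cnc(NCc2c(F)ccc3c2CCO3)c2cn[nH]c(=O)c12` gives 2.4. On these numbers compound 2 stands level with compound 3 at the digits shown, the two together the highest of the three, and it sits a number 0.60 log units higher from compound 1 to compound 3 (beyond the scatter) apart in the other direction from compound 1, a gap beyond the scatter; compound 2 and compound 3 differ within the scatter, so no order between them is claimed.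

The step under consideration leads from compound 2 to compound 4 `Cc1nn(C)cc1-c1cnc(NCc2c(F)ccc3c2CCO3)c2cn[nH]c(=O)c12`, not yet measured in this assay. The change is 1,3-dimethyl-1H-pyrazol-4-yl in place of 6-(hydroxymethyl)-2-methylpyridin-3-yl on an aromatic carbon. For the measured compounds named here, the one measured step in the set, a number 0.60 log units higher from compound 1 to compound 3 (beyond the scatter), concerns a different position and different groups, so it does not bear directly on this change; the data hold no step in which a hydroxymethyl-bearing pyridyl is exchanged for a dimethylpyrazolyl. What can be said is that the group leaving carries 1 hydrogen-bond donor and the group entering carries none, with two fewer heavy atoms. A modest upward step in this assay is therefore expected, a number 0.40 log units higher from compound 2 to compound 4 (beyond the scatter), though a result within the scatter would not surprise. For compound 4 the estimate is 2.8, ranging from 2.3 to 3.3.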

Compound 4, distribution coefficient: 2.8
Compound 4: the middle estimate sits on the measured number at the digits printed, and the stated range covers the measured number.
By their numbers in this assay, from the lowest: compound 1; then compounds 2 and 3 (each within the scatter of the next); then compound 4.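

The series now holds a measured step at this position on an aromatic carbon: in this assay 1,3-dimethyl-1H-pyrazol-4-yl in place of 6-(hydroxymethyl)-2-methylpyridin-3-yl gives a number 0.40 log units higher from compound 2 to compound 4 (beyond the scatter) and shows that this exchange moves the read-out beyond the scatter, which the earlier step, at a different place with different groups, could not show. Several things change together: a six-membered aromatic ring gives way to a five-membered one, the group leaving has 1 hydrogen-bond donor and 9 heavy atoms, the group entering has 0 hydrogen-bond donors and 7 heavy atoms, and both have 2 hydrogen-bond acceptors, so this single step cannot separate these changes. Nothing at hand accounts for the size of the step.

Going by these compounds, it stays open whether a plain methyl in place of the hydroxymethyl on the 2-methylpyridin-3-yl group would give a step of similar size, and how an amine or a carboxylic acid on that group would read. Also open, on these data alone, is whether the same exchange would give a similar step on the core of compound 1.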